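Swapping a Sulfonyl Cap for a Cyclopropylcarbonyl Cap

The source may hold more compounds than are shown below. What is called first, only, known or untested is meant among the compounds shown, and "the series" means these compounds.

Three compounds sharing a core were measured in an assay on CHO-K1 cells for displacement of a labelled ligand from melanin-concentrating hormone receptor 1 (Homo sapiens), read by scintillation proximity assay, with a stated time of 2 h; a lower number here means a stronger inhibitor, a higher number a weaker inhibitor. Compound 1 `Cc1ccc(/C=C/C(=O)Nc2ccc3nc(N4CCC(O)(C5CC5)CC4)nc(C)c3c2)cc1` gives 344 nM in this assay. Compound 2 `Cc1nc(NCCNS(C)(=O)=O)nc2ccc(NC(=O)/C=C/c3ccc(OC(F)(F)F)cc3)cc12` gives 169 nM, the lowest of the three numbers. Compound 3 `COCCC1(O)CCN(c2nc(C)c3cc(NC(=O)/C=C/c4ccc(Cl)cc4)ccc3n2)CC1` gives 245 nM, a number that sits within the usual scatter of that of compound 2, whereas the number of compound 1 lies beyond that scatter. Compound 4 `Cc1nc(NCCNC(=O)C2CC2)nc2ccc(NC(=O)/C=C/c3ccc(OC(F)(F)F)cc3)cc12` has not yet been measured. It differs from compound 2 in one place: cyclopropylcarbonyl in place of methylsulfonyl on an amine nitrogen. The change exchanges one small cap on the amine nitrogen for another and leaves the rest of the molecule untouched. Going by the values given here, no measured pair in this set isolates such a swap, so there is no direct precedent. The expectation for compound 4 is therefore a modest step in this assay, likely within the scatter, with no clear direction. Because compound 2 gives 169 nM, the estimate for compound 4 is 200 nM, with a range from 60 nM to 650 nM. This estimate corresponds to an expected step of a 1.2-fold higher number from compound 2 to compound 4 (0.07 log units; within the scatter).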

Compound 4, half-maximal inhibitory concentration: 61 nM
Compound 4: the middle estimate sits 3.3-fold (0.52 log units) above what was measured; low and high end bracket the measured number.
By their numbers in this assay, from the lowest: compound 4; then compounds 2, 3 and 1 (each within the scatter of the next, the first and the last beyond it).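

In this assay, going by these compounds alone, putting cyclopropylcarbonyl in place of methylsulfonyl on the amine nitrogen gives a 2.8-fold lower number from compound 2 to compound 4 (0.44 log units; beyond the scatter) and is the only single-place change available here. The earlier compounds shown here differ in several places at once, so they could not show that this cap alone can move the number beyond the usual scatter while the rest of the molecule stays fixed. No measurement here explains the step.

The compounds shown leave open whether the three-membered ring or the carbonyl goes with the lower number: acetyl on the same nitrogen would keep only the carbonyl, while cyclopropylsulfonyl would keep only the ring. Also open, going by these compounds, is whether a longer chain carrying the cyclopropylcarbonyl cap would keep the lower number.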